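The source may report more compounds than this note shows. Statements on the series, on what has been measured and on what is new or still open speak of the compounds shown alone.

Working notes on the series. Of the compounds shown here, two have numbers so far. Compound 2 `CCOc1ccc(-c2c(C#N)c(N)nc(SCc3ncc[nH]3)c2C#N)cc1` gives 11.7 nM in a functional assay on CHO cells for agonist activity at adenosine receptor A2b (Homo sapiens), read by AlphaScreen and cAMP accumulation (on this read-out higher numbers stand for an effect only at larger amounts of compound and lower numbers for an effect already at smaller amounts), and stands at the lower of the two numbers, with compound 1 `N#Cc1c(N)nc(SCC(N)=O)c(C#N)c1-c1ccc(OCC2CC2)cc1` at the higher, since compound 1 gives 31 nM in this assay. The two compounds differ in more than one place, so their gap is not attributed to any single change.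

Compound 3 `N#Cc1c(N)nc(SCc2ncc[nH]2)c(C#N)c1-c1ccc(OCC2CC2)cc1` is the next compound in line and has not yet been measured. It differs from compound 2 in one place: cyclopropyl in place of methyl on a saturated chain carbon bound to an oxygen on an aromatic ring. Among the compounds with values here, compound 1 already carries the cyclopropylmethoxy group, though with a different thioether substituent, so no step for this change alone exists among the measured compounds.

With nothing to set the size of this step, the expectation for compound 3 is a small step of a 1.0-fold higher number from compound 2 to compound 3 (0.01 log units; within the scatter) from compound 2, well within the scatter in either direction. Compound 3 is therefore estimated to give 12 nM in this assay, expected to fall between 5 nM and 30 nM.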

Compound 3, half-maximal effective concentration: 9.5 nM
The estimate for compound 3 lay 1.3-fold (0.10 log units) above the measured number; the range from low to high includes it.
By their numbers in this assay, from the lowest: compounds 3 and 2 (each within the scatter of the next); then compound 1.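

In this assay, within the data shown here, the change from ethoxy to cyclopropylmethoxy gives a 1.2-fold lower number from compound 2 to compound 3 (0.09 log units; within the scatter) and so can be read on its own for the first time: with the 1H-imidazol-2-yl thioether held constant, cyclopropyl in place of methyl on a saturated chain carbon bound to an oxygen on an aromatic ring leaves the two compounds indistinguishable in this read-out. The substituent on the saturated chain carbon bound to a sulfur now also has a one-place reading, since with cyclopropylmethoxy held constant, 1H-imidazol-2-yl in place of carbamoyl gives a 3.3-fold lower number from compound 1 to compound 3 (0.51 log units; beyond the scatter) as a modest step beyond the scatter. No measurement at hand accounts for the size of either step.

On these data alone, whether the carbamoyl to 1H-imidazol-2-yl step has the same size with ethoxy in place of cyclopropylmethoxy remains open, as does the reading at the oxygen for a longer chain such as n-butoxy or for benzyloxy. On the chain carbon bound to a sulfur, a carboxylic acid or a primary amine would show how far the step depends on the 1H-imidazol-2-yl group itself.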